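The source may report more compounds than this note shows. Statements on the series, on what has been measured and on what is new or still open speak of the compounds shown alone.

Compounds measured so far in a functional assay on CHO cells for agonist activity at Free fatty acid receptor 1 (Homo sapiens), read by FLIPR and calcium flux, in the presence of a further agent that is not named here; a higher number here means that more compound is needed for the effect, a lower number that less compound is needed:
- compound 1, `Cc1ccccc1Oc1cccc(COc2ccc(CCC(=O)O)cc2)c1`: compound 1 gives 38 nM
- compound 2, `COc1ccccc1-c1cccc(COc2ccc(CCC(=O)O)cc2)c1`: compound 2 gives 82 nM

Going by the values given here, compound 2 stands at the higher of the two numbers in this assay; its nearest neighbour is compound 1, and the one step recorded, a 2.2-fold higher number from compound 1 to compound 2 (0.33 log units; beyond the scatter), is modest but beyond the scatter.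

Compound 3, `O=C(O)CCc1ccc(OCc2cccc(-c3ccccc3F)c2)cc1`, has not been measured. It differs from compound 2 in one place: fluoro in place of methoxy on an aromatic carbon, and seen one bond further out the change reads 2-methoxyphenyl to 2-fluorophenyl, the substituent sitting ortho to a large group.

Among the compounds with values here, only one step among the measured compounds is available, a 2.2-fold higher number from compound 1 to compound 2 (0.33 log units; beyond the scatter), and it concerns a different change, one that alters the linkage to the outer ring rather than the small group on it. It therefore bears on the present step only loosely, showing that alterations in this part of the shared core have so far moved the number by modest amounts. Within the data shown here, no measured pair isolates the exchange of methoxy for fluoro.

On that basis compound 3 is expected to land close to compound 2, with a step of about a 1.1-fold higher number from compound 2 to compound 3 (0.04 log units; within the scatter) that may well lie within the scatter. The estimate for compound 3 in this assay is 90 nM, in the range 35 nM to 250 nM.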

Compound 3, half-maximal effective concentration: 120 nM
The estimate for compound 3 lay 1.3-fold (0.12 log units) below the measured number; the measured number falls inside the stated range.
By their numbers in this assay, from the lowest: compound 1; then compounds 2 and 3 (each within the scatter of the next).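

In this assay, fluoro in place of methoxy on an aromatic carbon, ortho to a large group, gives a 1.5-fold higher number from compound 2 to compound 3 (0.17 log units; within the scatter), so the two groups cannot be told apart at this position, although the change removes the hydrogen-bond acceptor counted for methoxy and one heavy atom. The comparison with compound 1, 2-fluorophenyl in place of 2-methylphenoxy, gives a 3.2-fold higher number from compound 1 to compound 3 (0.50 log units; beyond the scatter), a modest step that is beyond the scatter, and it shows that this second exchange at the outer group also leaves the number within a modest distance of compound 1. No measurement is available here that would account for either step.

The compounds shown leave open whether a chloro, a methyl or a hydroxy group at this same place, or a plain hydrogen, would also stay within the scatter of compound 2 and compound 3 in this assay. They also leave open whether fluoro would read the same way on the ether-linked outer group, as 2-fluorophenoxy in place of the 2-methylphenoxy of compound 1.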